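The source may report more compounds than this note shows. Statements on the series, on what has been measured and on what is new or still open speak of the compounds shown alone.

Series read in a toxicity assay on HeLa cells (Homo sapiens) for cytotoxicity; on this read-out higher numbers stand for lower toxicity in this test and lower numbers for higher toxicity in this test:
- compound 1 `COc1nc(-c2ccccc2F)ccc1[C@@H](c1ccccc1)[C@@](O)(CCN(C)C)c1cccc2ccccc12`: "nd" (no result reported), no result reported
- compound 2 `COc1ncc(-c2ccccc2)cc1[C@@H](c1ccccc1)[C@@](O)(CCN(C)C)c1cc(F)cc(F)c1`: 28.8 ug/mL
- compound 3 `COc1nc(-c2ccc(C(F)(F)F)cc2)ccc1[C@@H](c1ccccc1)[C@@](O)(CCN(C)C)c1cccc2ccccc12`: > 64 ug/mL, a limit of the assay and not a number

Among the measured compounds shown here, compound 2 holds the only actual number in this small set. Compound 3 gives a limit, and compound 1 gives no result, so neither offers a measured number for comparison. For the measured compounds named here, no step between measured compounds is available, and the expectation below has no measured step to lean on.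

The next compound to be read is compound 4 `COc1ncc(-c2ccccc2)cc1[C@@H](c1ccccc1)[C@@](O)(CCN(C)C)c1cccc(F)c1F`, which has the same atoms as compound 2, joined differently. The change is 2,3-difluorophenyl in place of 3,5-difluorophenyl on a saturated chain carbon bound to an oxygen on a saturated carbon and two saturated chain carbons. It sits on a saturated chain carbon bound to an oxygen on a saturated carbon and two saturated chain carbons, and the rest of the structure stays as it is.

Going by the values given here, the only anchor is compound 2 at 28.8 ug/mL, and the swap only moves the two fluorines around the same phenyl ring. No direction can be argued from these data, so no change beyond the usual scatter is expected. The expected shift is a 1.0-fold higher number from compound 2 to compound 4 (0.02 log units; within the scatter).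

For compound 4 the estimated value is 30 ug/mL, with an expected range of 14 ug/mL to 62 ug/mL.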

Compound 4, half-maximal cytotoxic concentration: 28.1 ug/mL
For compound 4 the middle estimate is 1.1-fold (0.03 log units) above the measured one; the range from low to high includes it.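

Among the compounds shown here, the only readable step in this assay is a 1.0-fold lower number from compound 2 to compound 4 (0.01 log units; within the scatter). With 2,3-difluorophenyl in place of 3,5-difluorophenyl on a saturated chain carbon bound to an oxygen on a saturated carbon and two saturated chain carbons, the two compounds read alike in this test, so this rearrangement of the two fluorines does not separate them, something the earlier set, with a single number in it, could not show. Neither compound 2 nor compound 4 gives a limit, so this comparison rests on two actual numbers and not on the ceiling of the read-out: the limit of > 64 ug/mL in this assay, at which 1 of the 4 values shown sits.

Compound 3 differs from compound 2 in more than one place, so the data shown do not tie its limit to any single change, and compound 1 adds no result to compare. From the compounds shown here alone, how a phenyl ring carrying an amine or a carboxylic acid in place of the two fluorines would read at this position remains open, as does whether any group there can move the value beyond the usual scatter.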